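The compounds below may be only part of what the source reports. "The series", "measured", "known", "first", "only" and "open" are said of these compounds alone.

Compound 3 `Cc1ccc(CN2C(=O)/C(=N\NC(=S)Nc3ccc(Cl)cc3)c3cc(Br)ccc32)cc1` gives the highest of the three numbers recorded in a functional assay on CCRF-CEM cells (Homo sapiens), with a stated time of 72 h (on this read-out higher numbers stand for weaker inhibition and lower numbers for stronger inhibition), namely 98000 nM. Its closest neighbour is compound 2 `O=C1/C(=N\NC(=S)Nc2ccc(Cl)cc2)c2cc(Br)ccc2N1Cc1ccc(F)cc1`, which in this assay gives 61000 nM; a 1.6-fold higher number from compound 2 to compound 3 (0.21 log units; within the scatter). Compound 1 `Cc1ccc(NC(=S)N/N=C2\C(=O)Nc3ccc(Br)cc32)cc1`, which carries no group on the ring nitrogen of the shared core, gives 6800 nM in this assay, a lower number than compound 3.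

Compound 4 `Cc1ccc(CN2C(=O)/C(=N\NC(=S)Nc3ccc(C)cc3)c3cc(Br)ccc32)cc1` differs from compound 3 in one place: methyl in place of chloro on an aromatic carbon. Among the compounds with values here, no measured step covers this exact exchange. Compound 1 also carries a 4-methylphenyl group, but it differs from compound 3 in a second place as well, so its value cannot be read as a guide to this single change. Within the data shown here, the only single-place step available, a 1.6-fold higher number from compound 2 to compound 3 (0.21 log units; within the scatter), concerns a different ring and stays within the scatter. Compound 4 is therefore expected to give 80000 nM in this assay, with a range from 30000 nM to 250000 nM, meaning an expected 1.2-fold lower number from compound 3 to compound 4 (0.09 log units; within the scatter) that is not beyond the scatter.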

Compound 4, half-maximal inhibitory concentration: >= 500000 nM
Compound 4 ended at the assay's limit; the forecaster's own chance of this, stated with the estimate: 15%; middle value at least 6.2-fold (0.79 log units) from the limit.
By their numbers in this assay, from the lowest: compound 1; then compounds 2 and 3 (each within the scatter of the next). At a limit, above all of these: compound 4.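

In this assay, methyl in place of chloro on this aromatic ring gives a clear change: an at least 5.1-fold higher number from compound 3 to compound 4 (0.70 log units; beyond the scatter). Within the data shown here, the only earlier single-place step concerned a different ring and stayed within the scatter, so this is the first sign that a one-atom exchange can matter on the shared core. With the 4-methylphenyl group held constant, adding 4-methylbenzyl on the ring nitrogen also goes with an at least 73-fold higher number from compound 1 to compound 4 (1.86 log units; beyond the scatter), and both sizes are minimums since the value of compound 4 is a limit of the assay, not a number: the limit of >= 500000 nM in this assay, at which 1 of the 4 values shown sits.

The compounds shown leave open how a methoxy group or an amine would read at this place on the ring. They also leave open whether methyl in place of chloro gives a step of similar size when the ring nitrogen carries hydrogen.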